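Lipophilicity notes on the cinnamanilide amine series

The compounds below may be only part of what the source reports. "The series", "measured", "known", "first", "only" and "open" are said of these compounds alone.

Measured so far in a physicochemical assay for lipophilicity, using the shake flask method, measured as octanol-water partition, at pH 7.4; a lower number here means a more polar compound, a higher number a more lipophilic compound:
compound 1 `COc1cc(/C=C/C(=O)Nc2ccccc2)ccc1OCCCCCN1CCCCC1` gives 1.65
compound 2 `COc1cc(/C=C/C(=O)Nc2ccccc2)ccc1OCCCCCCN1CCCC1` gives 1.76
compound 3 `CCN(CC)CCCCCCCCCCOc1ccc(/C=C/C(=O)Nc2ccccc2)cc1OC` gives 1.83

Compound 3 stands together with the other two: the steps of a number 0.18 log units higher from compound 1 to compound 3 (within the scatter) and a number 0.07 log units higher from compound 2 to compound 3 (within the scatter) both stay inside the scatter, as does a number 0.11 log units higher from compound 1 to compound 2 (within the scatter). The three amine end groups examined so far have not separated the series in this assay.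

Compound 4 `COc1cc(/C=C/C(=O)Nc2ccccc2)ccc1OCCCCCCCCCCN1CCCCC1` is not yet measured. The change from compound 3 is piperidin-1-yl in place of diethylamino on a saturated chain carbon, ten or more bonds along the chain from an oxygen on an aromatic ring. The most relevant measured step is a number 0.18 log units higher from compound 1 to compound 3 (within the scatter), which exchanges the same two groups in the other direction together with a change of chain, and it stayed within the scatter; a number 0.07 log units higher from compound 2 to compound 3 (within the scatter) likewise moved the amine end without a step beyond the scatter. No step beyond the scatter is therefore expected for compound 4 in this assay, with a number 0.07 log units higher from compound 3 to compound 4 (within the scatter) as the expected step. The estimate for compound 4 in this assay is 1.9, with a range from 1.5 to 2.3.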

Compound 4, partition coefficient: 1.83
Estimate against measurement, compound 4: 0.07 log units above; measured number inside the range.
By their numbers in this assay, from the lowest: compounds 1, 2, 3 and 4 (each within the scatter of the next).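

In this assay, going by these compounds alone, piperidin-1-yl in place of diethylamino on a saturated chain carbon gives no change at the digits printed from compound 3 to compound 4 (within the scatter); this is the first reading of this exchange alone, without a change of chain alongside it. The other two new steps, a number 0.07 log units higher from compound 2 to compound 4 (within the scatter) and a number 0.18 log units higher from compound 1 to compound 4 (within the scatter), also stay inside the scatter, so compound 4 adds no separation to the series at this position. No available evidence bears on this result.

From the compounds shown here alone, it remains open whether a morpholin-4-yl group, a primary amine or a carboxylic acid at the chain end would give a step beyond the scatter. Going by these compounds, a chain shorter than those in compounds 1 to 4, or a chloro substituent on the shared core, also remains open.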